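Methoxy step across two cores of the series

This account rests on a few compounds, and the source may have more. Where it says the series, first, only, none or still open, it means among the compounds named here.

The set holds three measured compounds and one awaiting measurement. Compound 1 `c1cc(C2=NCCN2)cc(-c2cc3cc(C4=NCCN4)ccc3o2)c1` and compound 2 `c1cc(-c2cc3ccc(C4=NCCN4)cc3o2)ccc1C1=NCCN1` share the same atoms joined differently; the difference between the two cores is not broken down here. In an ADME assay on L6 cells (Rattus norvegicus) for cytotoxicity (on this read-out lower numbers stand for stronger inhibition and higher numbers for weaker inhibition), compound 1 gives 33900 nM, while compound 2 gives 4500 nM, the lowest of the three numbers and beyond the scatter against both others. Compound 3 `COc1ccc(C2=NCCN2)cc1-c1cc2cc(C3=NCCN3)ccc2o1` carries the change methoxy in place of hydrogen on an aromatic carbon on the core of compound 1, and in this assay compound 3 gives 30800 nM; the step of a 1.1-fold lower number from compound 1 to compound 3 (0.04 log units; within the scatter) is within the scatter. Compound 4 `COc1cc(C2=NCCN2)ccc1-c1cc2ccc(C3=NCCN3)cc2o1` carries the change methoxy in place of hydrogen on an aromatic carbon on the core of compound 2. The placement differs: in compound 3 the methoxy is para to a group of 5 heavy atoms, in compound 4 meta to a group of 5 heavy atoms, so this is the same kind of change rather than the same change. Within the data shown here, the only measured instance, the step of a 1.1-fold lower number from compound 1 to compound 3 (0.04 log units; within the scatter), lies within the scatter. On that basis the expected step is a 1.1-fold lower number from compound 2 to compound 4 (0.03 log units; within the scatter). Compound 4 is estimated at 4200 nM in this assay, with a range from 2000 nM to 9000 nM.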

Compound 4, half-maximal inhibitory concentration: 4400 nM
Beside the measured number, compound 4's estimate is 1.0-fold (0.02 log units) below it, and the stated range covers the measured number.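

On the core of compound 2, the methoxy step in this assay reads a 1.0-fold lower number from compound 2 to compound 4 (0.01 log units; within the scatter), so the change gives no step beyond the scatter on this core. Set beside the earlier step, the result carries over between the two cores, and the two steps agree: the same change on two cores in this assay, a 1.1-fold lower number (0.04 log units; within the scatter) from compound 1 to compound 3 and a 1.0-fold lower number (0.01 log units; within the scatter) from compound 2 to compound 4, 1.1-fold (0.03 log units) apart, within the scatter of two such steps This does not show that methoxy would stay within the scatter at every placement or on other cores: the series offers one placement per core, ortho to a large group and meta to a group of 5 heavy atoms in compound 4 and a different placement in compound 3, and the comparison covers this read-out only.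

On these data alone, whether another group on the same aromatic carbon, such as a hydroxyl, an amine or a longer chain such as butoxy, would also stay within the scatter remains open. The compounds shown also leave open which part of the difference between the core of compound 1 and the core of compound 2 sets their numbers apart.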